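Ring swap on the aminopyrimidine: three measured, one awaited

This account rests on a few compounds, and the source may have more. Where it says the series, first, only, none or still open, it means among the compounds named here.

Measured so far in a functional assay on HCT-116 cells (Homo sapiens) for inhibition, read by MTT assay, with a stated time of 72 h, tested at 20 uM; on this read-out higher numbers stand for more inhibition at the one concentration tested (going by the name of the read-out) and lower numbers for less inhibition:
Compound 1, `CN(C)c1ccc(C(=O)Nc2ccc(Oc3ncnc4ccsc34)cc2)cc1`, gives 53.9%.
Compound 2, `CN(c1ccc(Oc2ncnc3ccsc23)cc1)c1nccc(N2CCCC2)n1`, gives 63.6%.
Compound 3, `CN(c1ccc(Oc2ncnc3ccsc23)cc1)c1nccc(N2CCc3ccccc3C2)n1`, gives 58.3%.

Compound 3 stands second highest of the three numbers; its nearest neighbour is compound 1, lower by an amount within the scatter, and its furthest is compound 2, higher by an amount that is also within the scatter. Compound 4, `CN(c1ccc(Oc2ncnc3ccsc23)cc1)c1nccc(N2CCCCC2)n1`, is reached from compound 3 by one change: piperidin-1-yl in place of 1,2,3,4-tetrahydroisoquinolin-2-yl on an aromatic carbon. Within the data shown here, the only measured step that bears on this is the ring exchange at the same place, a number 5.3 percentage points lower from compound 2 to compound 3 (within the scatter), which stayed within the scatter. A step of similar size is therefore expected in this assay, with no direction beyond the scatter, so that compound 4 is estimated at a number 1.7 percentage points higher from compound 3 to compound 4 (within the scatter). Compound 4 is expected to give 60%, within a range from 48% to 72%.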

Compound 4, a percentage reported as inhibition, at one concentration (the size of the read-out at that concentration, not a potency): 66.2%
Compound 4: middle estimate off by 6.2 percentage points, on the low side, and the stated range covers the measured number.
By their numbers in this assay, from the lowest: compounds 1, 3, 2 and 4 (each within the scatter of the next, the first and the last beyond it).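

At this aromatic carbon, piperidin-1-yl in place of 1,2,3,4-tetrahydroisoquinolin-2-yl gives, in this assay, a clear reading of the step (a number 7.9 percentage points higher from compound 3 to compound 4 (within the scatter)), and piperidin-1-yl in place of pyrrolidin-1-yl gives a second one (a number 2.6 percentage points higher from compound 2 to compound 4 (within the scatter)). With these steps, the three rings at this place all lie within the scatter of one another, so this exchange separates none of them on this read-out. Nothing at hand offers an explanation for this.

Going by these compounds, whether a morpholine or a piperazine at this place would stand apart from these three rings remains open.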